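Dropping a Methyl: What Compound 4 Is Expected to Show

The source may report more compounds than this note shows. Statements on the series, on what has been measured and on what is new or still open speak of the compounds shown alone.

Compound 1 `Cc1nnc(SCc2ccccc2)n1N1C(=O)c2ccccc2C1=O` gives, in a functional assay on HepG2 cells (Homo sapiens) for cytotoxicity, read by MTT assay, with a stated time of 48 h (on this read-out higher numbers stand for weaker inhibition and lower numbers for stronger inhibition), only a limit of the assay: > 200000 nM.
Compound 2 `CCOC(=O)CSc1nnc(C)n1N1C(=O)c2ccccc2C1=O` gives in this assay only a limit: > 200000 nM.
Compound 3 `Cc1ccc(C(=O)CSc2nnc(C)n2N2C(=O)c3ccccc3C2=O)cc1` gives in this assay only a limit: > 200000 nM.

Compound 3 thus stands at the same limit as the other two, and none of the three is told apart: the steps a step that the two limits leave unreadable from compound 1 to compound 2, a step that the two limits leave unreadable from compound 1 to compound 3 and a step that the two limits leave unreadable from compound 2 to compound 3 cannot be read, since (the limit of > 200000 nM in this assay, at which 3 of the 3 values shown sit). Compound 4 `Cc1nnc(SCC(=O)c2ccccc2)n1N1C(=O)c2ccccc2C1=O` differs from compound 3 by hydrogen in place of methyl on an aromatic carbon. Among the compounds with values here, no measured step involves this change, and the comparisons available give no size at all. For compound 4 in this assay the expected step is therefore a step that the limit leaves unreadable from compound 3 to compound 4, most likely ending again at a limit rather than a number. The estimate for compound 4 is 300000 nM, with a range from 100000 nM to 1000000 nM.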

Compound 4, half-maximal inhibitory concentration: > 200000 nM
Compound 4: no number, only a limit; the forecaster's own chance of this, stated with the estimate: 85%; the middle value lies beyond the limit too.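

In this assay compound 4 gives only a limit, > 200000 nM. Within the data shown here, no step from compound 1, compound 2 or compound 3 to compound 4 can be read: the limit of > 200000 nM in this assay, at which 4 of the 4 values shown sit. Whether any change among these four compounds alters their effect on the cells stays open.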